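The source may hold more compounds than are shown below. What is called first, only, known or untested is meant among the compounds shown, and "the series" means these compounds.

Working notes on the series, read in an ADME assay on CHO cells (Cricetulus griseus) for cytotoxicity, read by MTT assay, with a stated time of 24 h; a lower number here means that less compound is tolerated, a higher number that more compound is tolerated. Compound 3 `CC1Cn2c(nc([N+](=O)[O-])c2-c2ccccc2)O1` gives > 500000 nM, which is a limit and not a number. Compound 1 `CC1Cn2c(nc([N+](=O)[O-])c2-c2ccc(CO)cc2)O1` gives > 500000 nM, also a limit. Compound 2 `CC1Cn2c(nc([N+](=O)[O-])c2-c2ccc(Cl)cc2)O1` gives > 250000 nM, again a limit. Compound 3 therefore has no exact position in the series, and none of the three compounds has a measured number.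

The next change leads to compound 4 `CCCOc1ccc(-c2c([N+](=O)[O-])nc3n2CC(C)O3)cc1`, with propoxy in place of hydrogen on an aromatic carbon. The nearest evidence is the set of changes on an aromatic carbon: a step that the two limits leave unreadable from compound 1 to compound 3, a step that the two limits leave unreadable from compound 2 to compound 3 and a step that the two limits leave unreadable from compound 1 to compound 2. None of these has a readable size, and none involves propoxy, so they give no measured size or direction to carry over.

Compound 3 at > 500000 nM also offers only a limit as a starting point, so the expectation stays loose. A modest move toward less compound being tolerated is allowed for, and another limit reading remains quite possible. The estimated change is an at least 2.5-fold lower number from compound 3 to compound 4 (0.39 log units; beyond the scatter). Compound 4 is expected at 200000 nM, with an estimated range from 50000 nM to 500000 nM.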

Compound 4, half-maximal cytotoxic concentration: > 125000 nM
Compound 4 ended at the assay's limit (the forecaster's own chance of this, stated with the estimate: 60%); the middle value does not contradict the limit.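

In this assay compound 4 gives > 125000 nM, which is a limit and not a number. Its steps to compound 1, compound 2 and compound 3 therefore cannot be read. The compounds shown leave open whether propoxy, chloro, hydroxymethyl or hydrogen on the aromatic carbon makes any difference to how much compound is tolerated.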